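Shortening the Chain on the Ring Nitrogen

The source may hold more compounds than are shown below. What is called first, only, known or untested is meant among the compounds shown, and "the series" means these compounds.

Compound 1 `O=C(/C=C/c1cn([C@@H]2C[C@H](C(=O)O)N(CCCc3ccccc3)C2)nn1)NO` was tested in an assay on Sf9 cells for inhibition of histone deacetylase 11 (Homo sapiens), read by fluorescence, tested at 0.5 uM (on this read-out higher numbers stand for more inhibition at the one concentration tested (going by the name of the read-out) and lower numbers for less inhibition), where compound 1 gives 11%. Among the compounds with values here, on this read-out it stands lowest of the two numbers measured so far. Its partner compound 2 `O=C(/C=C/c1cn([C@H]2C[C@H](C(=O)O)N(CCCc3ccccc3)C2)nn1)NO` gives 20% in this assay. The step from one to the other is a number 9 percentage points higher from compound 1 to compound 2 (within the scatter), and it rests on (the fact that compounds 1 and 2 differ only in the configuration as drawn).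

Compound 3 `O=C(/C=C/c1cn([C@@H]2C[C@H](C(=O)O)N(Cc3ccccc3)C2)nn1)NO` has not yet been measured. It differs from compound 1 by phenyl in place of phenethyl on a saturated chain carbon bound to an amine nitrogen in a ring. Within the data shown here, the only measured step, that between compound 1 and compound 2, changes configuration and leaves the chain untouched, so it carries no information about what shortening the chain does. Among the measured compounds shown here, no measured step bears on this change. The expected step of a number 1 percentage points higher from compound 1 to compound 3 (within the scatter) is therefore none beyond the scatter. Compound 3 is estimated at 12%, with a range from 0% to 35%.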

Compound 3, a percentage reported as inhibition, at one concentration (the size of the read-out at that concentration, not a potency): < 10%
Compound 3: only a limit was reported (the forecaster's own chance of this, stated with the estimate: 0%); at least 2 percentage points between middle value and limit.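

In this assay compound 3 gives < 10%, which is a limit of the assay and not a number. Within the data shown here, the only measured change to the chain on the amine nitrogen in a ring, 3-phenylpropyl to benzyl, reads a number at least 1 percentage points lower from compound 1 to compound 3 (that floor lies within the scatter), so this shorter chain brings no rise in inhibition at the one concentration tested. How far apart the two compounds lie cannot be read, because the value of compound 3 is cut off at the limit: the limit of < 10% in this assay, at which 1 of the 3 values shown sits.

Going by these compounds, it remains open whether a longer chain such as 4-phenylbutyl, or a chain ending in an amine, on the same nitrogen would raise the inhibition in this assay. On these data alone, it is also open whether the benzyl group would give a similar result with the configuration drawn in compound 2.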